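Swapping the aryl on the ring nitrogen of compound 3

The source may hold more compounds than are shown below. What is called first, only, known or untested is meant among the compounds shown, and "the series" means these compounds.

Three compounds share a core built around a two-carbon amide linker attached to an aromatic ring carrying an isobutyl group. Compound 1 `CC(C)Cc1ccc(C(C)C(=O)NCc2ccccc2)cc1` carries a benzyl group on the amide nitrogen, and in an assay on brain for inhibition of Fatty-acid amide hydrolase 1 (Rattus norvegicus), read by scintillation counting, with a stated time of 10 min (a higher number here means a weaker inhibitor, a lower number a stronger inhibitor), compound 1 gives 21000 nM. Compound 2 `COc1ccccc1CNC(=O)C(C)c1ccc(CC(C)C)cc1` adds a methoxy group on an aromatic carbon of that benzyl, and in this assay compound 2 gives 18000 nM; the step of a 1.2-fold lower number from compound 1 to compound 2 (0.07 log units; within the scatter) shows that this change made no difference beyond the scatter. Compound 3 `CC(C)Cc1ccc(C(C)C(=O)N2CCN(c3ccc(Cl)cc3)CC2)cc1` instead closes the amide nitrogen into a six-membered non-aromatic ring with two nitrogens, the second nitrogen carrying a 4-chlorophenyl group; in this assay compound 3 gives 1700 nM, the strongest inhibitor of the three, with both other compounds giving higher numbers that lie beyond the scatter.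

Compound 4 `Cc1cccc(N2CCN(C(=O)C(C)c3ccc(CC(C)C)cc3)CC2)c1` differs from compound 3 by one change: 3-methylphenyl in place of 4-chlorophenyl on an amine nitrogen in a ring. Among the compounds with values here, no measured step changes this aryl group, and the only single-place step available, from compound 1 to compound 2, is an aromatic substituent change that stayed within the scatter. An exchange of one small aromatic substituent for another is therefore expected to give at most a modest step of a 1.6-fold higher number from compound 3 to compound 4 (0.22 log units; within the scatter), with a weaker result slightly more likely than a stronger one. Compound 4 is estimated at 2800 nM, with a plausible range from 900 nM to 9000 nM.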

Compound 4, half-maximal inhibitory concentration: 16000 nM
Compound 4: middle estimate off by 5.7-fold (0.76 log units), on the low side, and the stated range ends below it.
By their numbers in this assay, from the lowest: compound 3; then compounds 4, 2 and 1 (each within the scatter of the next).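

In this assay, the swap of 4-chlorophenyl for 3-methylphenyl gives a 9.4-fold higher number from compound 3 to compound 4 (0.97 log units; beyond the scatter), so the aryl group on this amine nitrogen in a ring clearly matters, even though both groups have the same heavy-atom count and neither has hydrogen-bond donors or acceptors. The earlier substituent change on the benzyl group gave a 1.2-fold lower number from compound 1 to compound 2 (0.07 log units; within the scatter), so a small aromatic change can pass within the scatter at one place yet not at another. No measurement shown here explains this large step.

The swap changes both the substituent and its place on the aromatic ring, and the compounds shown cannot separate those two changes. Pairs with 3-chlorophenyl and 4-methylphenyl would address this, while the effect of a methoxy group or a carboxylic acid on this aryl ring remains open.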